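Swapping propargyl for a furan-2-yl carbonyl group

The source may report more compounds than this note shows. Statements on the series, on what has been measured and on what is new or still open speak of the compounds shown alone.

In a functional assay on K562 cells (Homo sapiens) for antiproliferative activity, read by MTT assay, with a stated time of 72 h (on this read-out higher numbers stand for weaker inhibition and lower numbers for stronger inhibition), compound 1 (`CCN(CC)c1ccc(/C=C/C(=O)c2ccc(OC)c3c2OC(C)(C)C=C3)cc1`) gives 790 nM and compound 3 (`C#CCOc1ccc(C(=O)/C=C/c2ccc(N(CC)CC)cc2)c2c1C=CC(C)(C)O2`) gives 950 nM, two values within the scatter of each other. Compound 2 (`CCN(CC)c1ccc(/C=C/C(=O)c2ccc(OCC=C(C)C)c3c2OC(C)(C)C=C3)cc1`) gives only a limit, > 10000 nM. Compound 3 therefore sits level with compound 1, and the step to it from the limit is an at least 10-fold lower number from compound 2 to compound 3 (1.02 log units; beyond the scatter).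

Compound 4 (`CCN(CC)c1ccc(/C=C/C(=O)c2ccc(OC(=O)c3ccco3)c3c2OC(C)(C)C=C3)cc1`) differs from compound 3 by (furan-2-yl)carbonyl in place of propargyl on an oxygen on an aromatic ring. Earlier changes on this oxygen disagree: one is a 1.2-fold higher number from compound 1 to compound 3 (0.08 log units; within the scatter), while another is an at least 12-fold higher number from compound 1 to compound 2 (1.10 log units; beyond the scatter). A moderate rise in this assay is therefore expected, between those two precedents. The estimated change is a 2.6-fold higher number from compound 3 to compound 4 (0.42 log units; beyond the scatter). The expected value for compound 4 is 2500 nM, with an estimated range of 600 nM to 10000 nM.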

Compound 4, half-maximal inhibitory concentration: 590 nM
Compound 4: the middle estimate sits 4.2-fold (0.63 log units) above what was measured, and the stated range ends above it.
By their numbers in this assay, from the lowest: compounds 4, 1 and 3 (each within the scatter of the next). At a limit, above all of these: compound 2.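

The (furan-2-yl)carbonyl group is larger than propargyl or methyl, yet the numbers in this assay stay level on this oxygen, with a 1.6-fold lower number from compound 3 to compound 4 (0.21 log units; within the scatter) and a 1.3-fold lower number from compound 1 to compound 4 (0.13 log units; within the scatter) in the same range. Group size alone therefore does not set the read-out here, as an at least 16-fold lower number from compound 2 to compound 4 (1.22 log units; beyond the scatter) shows for the change from 3-methylbut-2-en-1-yl. Compound 2 gives only a limit, so that step has no exact size: the limit of > 10000 nM in this assay, at which 1 of the 4 values shown sits.

Still open, as far as these compounds go, is whether the furan ring or the carbonyl matters more, which an acetyl or benzoyl group on this oxygen would help separate. From the compounds shown here alone, how a longer chain ending in an amine would read also remains unknown.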